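This account rests on a few compounds, and the source may have more. Where it says the series, first, only, none or still open, it means among the compounds named here.

In a functional assay on Lewis lung carcinoma cells (Mus musculus) for antiproliferative activity, read by MTT assay, with a stated time of 24 h (on this read-out higher numbers stand for weaker inhibition and lower numbers for stronger inhibition), compound 1 (`C=CCc1cc(-c2ccccc2)ccc1O`) gives > 100000 nM, which is a limit of the assay and not a number. Compound 2 (`C=CCc1cc(-c2ccc(NC(C)=O)cc2)ccc1OC`) gives 65100 nM and compound 3 (`C=CCc1cc(-c2cccc([N+](=O)[O-])c2)cc(CC=C)c1O`) gives 56500 nM, so these two compounds stand within the usual scatter of each other. Compound 4 (`C=CCc1cc(-c2ccc(C(F)(F)F)cc2)ccc1OC`) departs from compound 2 in one place: trifluoromethyl in place of acetamido on an aromatic carbon. Trifluoromethyl takes the place of acetamido on an aromatic carbon, para to a large group. Going by the values given here, no pair of measured compounds shows this change alone, so no shift beyond the scatter is expected in this assay, in either direction. The expected step is a 1.1-fold lower number from compound 2 to compound 4 (0.04 log units; within the scatter). For compound 4 the estimated value is 60000 nM, with an expected range from 25000 nM to 100000 nM.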

Compound 4, half-maximal inhibitory concentration: 78800 nM
Estimate against measurement, compound 4: 1.3-fold (0.12 log units) below, and the stated range covers the measured number.
By their numbers in this assay, from the lowest: compounds 3, 2 and 4 (each within the scatter of the next). At a limit, above all of these: compound 1.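

In this assay, the exchange on an aromatic carbon, para to a large group, gives the first step read in one place: a 1.2-fold higher number from compound 2 to compound 4 (0.08 log units; within the scatter). Trifluoromethyl, with 0 hydrogen-bond donors, and acetamido, with 1, thus stand within the scatter of each other at this position. Compound 4 gives a number and not a limit, so this step can be read, and the assay does have a limit: the limit of > 100000 nM in this assay, at which 1 of the 4 values shown sits.

Going by these compounds, whether an amine or a carboxylic acid at this position would stand apart from these two groups stays open. So does whether the same exchange would read alike on the core of compound 1.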